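The compounds below may be only part of what the source reports. "The series", "measured", "known", "first", "only" and "open" are said of these compounds alone.

Three compounds share one core. Compound 1 `COc1nc(C)nc(/N=C/c2ccccc2)n1` has in an ADME assay on Vero cells (Chlorocebus sabaeus) for cytotoxicity, read by MTT assay, with a stated time of 72 h (a lower number here means a stronger inhibitor, a higher number a weaker inhibitor), the entry "not determined" (no result reported). Compound 2 `COc1nc(C)nc(/N=C/c2ccc(C)cc2)n1` gives in this assay only a limit, > 50 ug/mL. Compound 3 `COc1nc(C)nc(/N=C/c2ccc(Cl)cc2)n1` likewise gives in this assay only a limit, > 50 ug/mL. The step that the two limits leave unreadable from compound 2 to compound 3 is therefore not readable, which matches (the limit of > 50 ug/mL in this assay, at which 2 of the 3 values shown sit). Compound 3 thus stands at a limit rather than a number, as does one further entry, while the third entry carries no number at all. Compound 4 `COc1nc(C)nc(/N=C/c2ccc(Cl)cc2Cl)n1` differs from compound 3 by chloro in place of hydrogen on an aromatic carbon. Among the compounds with values here, no measured step reads on this change, since the only one is unreadable. Compound 4 is therefore expected to remain at the limit, the expected step of a number no higher from compound 3 to compound 4 (the limit leaves the size open) being none beyond the scatter. The estimate for compound 4 is 50 ug/mL, between 30 ug/mL and 100 ug/mL.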

Compound 4, half-maximal inhibitory concentration: > 50 ug/mL
Compound 4: a limit, no number (the forecaster's own chance of this, stated with the estimate: 75%); the middle value lies on the limit itself.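

Within the data shown here, compound 3 and compound 4 each give only a limit in this assay, and no step between them can be read. The compounds shown leave open whether the added chloro changes the read-out at all, and where any of their actual values lie.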